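The source may report more compounds than this note shows. Statements on the series, on what has been measured and on what is new or still open speak of the compounds shown alone.

Measured in a functional assay on VCaP cells (Homo sapiens) for antiproliferative activity, read by CCK-8 assay, with a stated time of 6 days; a lower number here means a stronger inhibitor, a higher number a weaker inhibitor:
- compound 1 `CCN(c1ccc(C#N)c(Cl)c1)c1cc(-c2cncnc2)ccc1C`: 3920 nM
- compound 2 `CCN(c1ccc(C#N)c(Cl)c1)c1cc(-c2ccnn2C)ccc1C`: 1670 nM
- compound 3 `CCN(c1ccc(C#N)c(Cl)c1)c1cc(C2=CCCCC2)ccc1C`: 20000 nM

Of these three, compound 3 has the highest number, 20000 nM, and so is the weakest inhibitor. The next compound, compound 4 `CCN(c1ccc(C#N)c(Cl)c1)c1cc(-n2cccn2)ccc1C`, has not yet been measured. It carries 1H-pyrazol-1-yl in place of cyclohex-1-en-1-yl on an aromatic carbon.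

Among the compounds with values here, two measured steps bear on this change, both running the opposite way. The modest 5.1-fold higher number from compound 1 to compound 3 (0.71 log units; beyond the scatter) and the large 12-fold higher number from compound 2 to compound 3 (1.08 log units; beyond the scatter) each install cyclohex-1-en-1-yl in place of an aromatic ring, and each raises the number. Undoing that exchange should therefore lower the number in this assay. Within the data shown here, no measured compound carries 1H-pyrazol-1-yl itself. The nearest group by name is the 1-methyl-1H-pyrazol-5-yl of compound 2, while a 2.3-fold lower number from compound 1 to compound 2 (0.37 log units; beyond the scatter) shows that the choice of aromatic ring matters beyond the scatter. A sizeable drop is thus expected, landing near the two aromatic compounds rather than near compound 3. The expected change is an 8.0-fold lower number from compound 3 to compound 4 (0.90 log units; beyond the scatter). For compound 4 the estimated value is 2500 nM, with an expected range of 800 nM to 8000 nM.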

Compound 4, half-maximal inhibitory concentration: 2340 nM
Estimate against measurement, compound 4: 1.1-fold (0.03 log units) above; measured number inside the range.
By their numbers in this assay, from the lowest: compounds 2, 4 and 1 (each within the scatter of the next, the first and the last beyond it); then compound 3.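

In this assay, 1H-pyrazol-1-yl in place of cyclohex-1-en-1-yl gives an 8.5-fold lower number from compound 3 to compound 4 (0.93 log units; beyond the scatter), which shows that this position, on an aromatic carbon para to a methyl group, also accepts an aromatic ring joined through a ring nitrogen, and not only the two rings joined through carbon. The new group cannot be told apart from either earlier aromatic ring, since both a 1.4-fold higher number from compound 2 to compound 4 (0.15 log units; within the scatter) and a 1.7-fold lower number from compound 1 to compound 4 (0.22 log units; within the scatter) lie within the scatter, even though the step between those two rings, a 2.3-fold lower number from compound 1 to compound 2 (0.37 log units; beyond the scatter), lies beyond it; the three aromatic rings therefore form one group here, with compound 3 standing apart from all of them. Nothing available explains why the aromatic rings and the cyclohex-1-en-1-yl group differ in this way.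

On these data alone, it remains open whether a saturated ring carrying an amine, such as piperidine, or a carboxylic acid at this place would fall with the aromatic rings or with compound 3. As far as these compounds go, it is also open whether a methyl group or a nitrile on the 1H-pyrazol-1-yl ring would move the number beyond the scatter.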